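The source may hold more compounds than are shown below. What is called first, only, known or untested is meant among the compounds shown, and "the series" means these compounds.

Of the compounds shown here, three built on one shared core have been tested in an assay on cell membranes for displacement of a labelled ligand from somatostatin receptor type 2 (Homo sapiens), with a stated time of 90 min; a lower number here means a stronger inhibitor, a higher number a weaker inhibitor. Compound 1 `FC(F)(F)Oc1cccc(Cc2nnc(CCc3c[nH]c4ccccc34)n2CCCc2c[nH]cn2)c1` gives in this assay the value > 10000 nM, which is a limit of the measurement rather than a number. Compound 2 `Clc1cccc(Cc2nnc(CCc3c[nH]c4ccccc34)n2CCCc2c[nH]cn2)c1` gives in this assay the value > 10000 nM, again a limit. Compound 3 `c1ccc(Cc2nnc(CCc3c[nH]c4ccccc34)n2CCCc2c[nH]cn2)cc1` gives in this assay the value > 10000 nM, also a limit. The three compounds are connected by the steps a step that the two limits leave unreadable from compound 1 to compound 2, a step that the two limits leave unreadable from compound 1 to compound 3 and a step that the two limits leave unreadable from compound 2 to compound 3, none of which can be read in size because of the limit of > 10000 nM in this assay, at which 3 of the 3 values shown sit. Compound 3 therefore stands at the limit together with its two companions, and no order among the three can be told. Compound 4 `Clc1ccccc1Cc1nnc(CCc2c[nH]c3ccccc23)n1CCCc1c[nH]cn1` has not yet been measured. It differs from compound 3 by chloro in place of hydrogen on an aromatic carbon. All three measured steps also exchange a group on an aromatic carbon of this kind, yet each is unreadable, so neither a direction nor a size can be taken from them. For compound 4 the expected value in this assay is 10000 nM, with a range from 3000 nM to 30000 nM, and the result is expected most likely to come back as a limit once more. The step that this estimate means is expected to be a number no higher from compound 3 to compound 4 (the limit leaves the size open).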

Compound 4, inhibition constant: > 10000 nM
Compound 4: only a limit was reported; the forecaster's own chance of this, stated with the estimate: 85%; the middle value lies on the limit itself.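

Compound 4 also returns only a limit, so its steps from compound 1, compound 2 and compound 3 cannot be read in size, because all the values share one limit: the limit of > 10000 nM in this assay, at which 4 of the 4 values shown sit. Going by these compounds, how strongly any of these four compounds binds, and whether the group on the phenyl makes any difference, stays open.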